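Swapping chloro for hydroxy in a growth inhibition series

This account rests on a few compounds, and the source may have more. Where it says the series, first, only, none or still open, it means among the compounds named here.

Compounds measured so far in a functional assay on MCF7 cells (Homo sapiens) for inhibition, read by fluorescence, with a stated time of 72 h (on this read-out lower numbers stand for stronger inhibition of growth and higher numbers for weaker inhibition of growth), and their values:
- compound 1 `CC(C)CCn1cnc2c(Nc3ccc(Cl)cc3)nc(N[C@H]3CC[C@H](N)CC3)nc21` with 2700 nM
- compound 2 `CCCCn1cnc2c(Nc3ccc(Cl)cc3)nc(N[C@H]3CC[C@H](N)CC3)nc21` with 2100 nM

Only these two numbers exist, and they lie within the scatter of each other, so compound 1 stands level with compound 2. The next compound to be tested is compound 3 `CC(C)CCn1cnc2c(Nc3ccc(O)cc3)nc(N[C@H]3CC[C@H](N)CC3)nc21` which keeps the chain of compound 1. Its change is hydroxy in place of chloro on an aromatic carbon, para to a large group (hydroxy in place of chloro on an aromatic carbon). Within the data shown here, the one measured step (a 1.3-fold lower number from compound 1 to compound 2 (0.11 log units; within the scatter)) lies on the saturated chain, not on this aromatic carbon, so it bears on the new change only indirectly. Among the measured compounds shown here, no measured pair shows what replacing chloro does, and the data offer no direction for it. The central expectation is therefore no shift beyond the scatter, with a wide margin on both sides. The estimated step (a 1.1-fold higher number from compound 1 to compound 3 (0.05 log units; within the scatter)) reflects that expectation. Compound 3 is expected to give 3000 nM in this assay (estimated range 800 nM to 11000 nM).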

Compound 3, concentration for 50% growth inhibition: 3100 nM
Estimate against measurement, compound 3: 1.0-fold (0.01 log units) below; the measured number falls inside the stated range.
By their numbers in this assay, from the lowest: compounds 2, 1 and 3 (each within the scatter of the next).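

In this assay, among these compounds, the first measured change on the 4-chlorophenyl group, hydroxy in place of chloro, gives a 1.1-fold higher number from compound 1 to compound 3 (0.06 log units; within the scatter). Among the compounds shown here, at this aromatic carbon, then, the two groups cannot be told apart on this read-out, even though hydroxy brings a hydrogen-bond donor and a hydrogen-bond acceptor that chloro does not count, so this position now has one measured change where the earlier compounds offered only a step on the saturated chain. Nothing measured on these compounds speaks to why the two groups read alike.

This is a single pair on a single chain, so whether the same swap would read the same on the chain of compound 2 remains an open question. Also open, on these data alone, is whether a different group on this aromatic carbon, such as an amine, a methoxy group or a plain hydrogen, would carry the number beyond the scatter in either direction, which would show whether this position responds to change at all.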